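The source may report more compounds than this note shows. Statements on the series, on what has been measured and on what is new or still open speak of the compounds shown alone.

In a functional assay on A498 cells (Homo sapiens) for inhibition (a lower number here means a stronger inhibitor of growth, a higher number a weaker inhibitor of growth), the three measured compounds lie far apart. Compound 1, `COc1cc(/C=C/C(=O)c2cccc(-n3cc(-c4ccc(Cl)cc4)[nH]c3=O)c2)cc(OC)c1OC`, gives 30200 nM. Compound 3, `O=C(/C=C/c1cccc(O)c1)c1cccc(-n2cc(-c3ccccc3)[nH]c2=O)c1`, gives 14300 nM. Compound 2, `COc1cc(/C=C/C(=O)c2cccc(-n3cc(-c4ccccc4)[nH]c3=O)c2)ccc1O`, gives 1680 nM, the lowest of the three numbers, with compound 3 nearest to it and compound 1 furthest away. Within the data shown here, the only single-point step among them, an 8.5-fold higher number from compound 2 to compound 3 (0.93 log units; beyond the scatter), changes the ring at the end of the double-bonded chain, 3-hydroxyphenyl in place of 4-hydroxy-3-methoxyphenyl. Compound 4, `COc1ccc(-c2cn(-c3cccc(C(=O)/C=C/c4ccc(O)c(OC)c4)c3)c(=O)[nH]2)cc1`, changes the other ring instead: methoxy in place of hydrogen on an aromatic carbon, on an aromatic carbon of a six-membered aromatic ring of carbon only, para to a large group, which cut one bond further out reads phenyl to 4-methoxyphenyl. Among the measured compounds shown here, no measured step addresses this ring on its own, and compound 1 differs from compound 2 in two places at once, so it cannot guide the step. The estimated change is therefore a 1.5-fold higher number from compound 2 to compound 4 (0.17 log units; within the scatter), a step not expected to go beyond the scatter. For compound 4 the expected value is 2500 nM, within a range from 800 nM to 8000 nM.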

Compound 4, concentration for 50% growth inhibition: 3720 nM
For compound 4 the middle estimate is 1.5-fold (0.17 log units) below the measured one; the range from low to high includes it.
By their numbers in this assay, from the lowest: compound 2; then compound 4; then compound 3; then compound 1.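

Among these compounds, this is the first step that changes only the phenyl group left untouched by the earlier single-place comparison: in this assay, phenyl to 4-methoxyphenyl gives a 2.2-fold higher number from compound 2 to compound 4 (0.35 log units; beyond the scatter). The step is modest but real, so a methoxy group is tolerated at this position with some weakening of growth inhibition, and compound 2 keeps the lowest number. Nothing available explains why this change raises the number.

The compounds shown leave open whether another group at this same place, such as an amine or a carboxylic acid, would raise the number further or bring it back down. From the compounds shown here alone, the effect of 4-chlorophenyl alone also remains unknown, as compound 1 carries it together with a second change.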